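Two Compounds at the Assay Limit, a Third to Come

The source may hold more compounds than are shown below. What is called first, only, known or untested is meant among the compounds shown, and "the series" means these compounds.

Measured so far:
compound 1 `COc1cc2ncnc(Nc3ccc(F)c(Cl)c3)c2cc1B(O)O` gives > 1000 nM
compound 2 `COc1cc2ncnc(Nc3cccc(Cl)c3)c2cc1B(O)O` gives > 1000 nM

In an assay on isolated protein for inhibition of vascular endothelial growth factor receptor 1 (Homo sapiens), read by ELISA, with a stated time of 20 min (a lower number here means a stronger inhibitor, a higher number a weaker inhibitor), compound 1 gives > 1000 nM, and this is a limit of the assay, not a number. Compound 2 likewise gives > 1000 nM in this assay, again a limit. Among the compounds with values here, both values sit at the limit of > 1000 nM in this assay, at which 2 of the 2 values shown sit, so the single measured step, a step that the two limits leave unreadable from compound 1 to compound 2, cannot be read in size or direction. Compound 1 therefore stands only at a limit, and nothing shown places it more precisely.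

Compound 3 `COc1cc2ncnc(Nc3ccc(F)c(Cl)c3)c2cc1B1OC(C)(C)C(C)(C)O1` differs from compound 1 by a group of 9 heavy atoms (6 carbon, 1 boron, 2 oxygen; one five-membered non-aromatic ring with 3 hetero atoms) in place of a group of 3 heavy atoms (1 boron, 2 oxygen; no ring), on an aromatic carbon ortho to a methoxy group. Within the data shown here, no measured step touches this position, and the one step that exists is unreadable, so no size of change in this assay can be inferred from the data. Compound 3 is expected to remain at or beyond the limit, with an estimated value of 3000 nM, ranging from 1000 nM to 30000 nM. The expected step from compound 1 is a step that the limit leaves unreadable from compound 1 to compound 3, which is expected to be unreadable against the limit.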

Compound 3, half-maximal inhibitory concentration: > 1000 nM
Compound 3 ended at the assay's limit (the forecaster's own chance of this, stated with the estimate: 80%); the middle value does not contradict the limit.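

In this assay compound 3 gives > 1000 nM, a limit of the assay and not a number. Compound 1 also stands only at a limit, so no new step can be read between compound 1 and compound 3: the limit of > 1000 nM in this assay, at which 3 of the 3 values shown sit.

The compounds shown leave open how strongly compound 1, compound 2 or compound 3 inhibits the receptor, and what either change of group does in this assay.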